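A few compounds are considered here, and "the series" means these few. Any claim that something is new, unique, unknown or untested is made for them only; others in the source may bear on it.

Measured so far in an ADME assay on CHO cells (Cricetulus griseus) for cytotoxicity, read by MTT assay, with a stated time of 24 h; on this read-out lower numbers stand for higher toxicity in this test and higher numbers for lower toxicity in this test:
Compound 1 `Cc1ccc(C#Cc2c([N+](=O)[O-])nc3n2CC(C)O3)cc1`: 5470 nM
Compound 2 `CC1Cn2c(nc([N+](=O)[O-])c2C#CC2CC2)O1`: 6450 nM

Going by the values given here, with only two compounds measured, compound 2 cannot be set apart from compound 1, as the two values lie within the usual scatter of each other.

Compound 3 `CC1Cn2c(nc([N+](=O)[O-])c2C#Cc2cccc(N)c2)O1` is not yet measured. It keeps the core of compound 2 and has 3-aminophenyl in place of cyclopropyl on a triple-bonded carbon.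

Among the compounds with values here, one measured step bears on this change: a 1.2-fold higher number from compound 1 to compound 2 (0.07 log units; within the scatter). It exchanged a group holding a six-membered aromatic ring for cyclopropyl at the same place, and the number stayed within the scatter. Compound 3 brings such a ring back, so a similar result is expected. Within the data shown here, no measured compound carries the 3-aminophenyl group, however, so its effect remains unknown and the range must stay wide.

No step beyond the scatter is therefore expected, and the estimated change is a 1.2-fold lower number from compound 2 to compound 3 (0.07 log units; within the scatter).

For compound 3 the estimated value is 5500 nM, with an expected range of 2500 nM to 11000 nM.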

Compound 3, half-maximal cytotoxic concentration: 18100 nM
Beside the measured number, compound 3's estimate is 3.3-fold (0.52 log units) below it; measured number outside the range, above it.
By their numbers in this assay, from the lowest: compounds 1 and 2 (each within the scatter of the next); then compound 3.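

In this assay, the group on this triple-bonded carbon can shift the number beyond the scatter: 3-aminophenyl gives a 2.8-fold higher number from compound 2 to compound 3 (0.45 log units; beyond the scatter) and also a 3.3-fold higher number from compound 1 to compound 3 (0.52 log units; beyond the scatter), whereas the earlier exchange of 4-methylphenyl for cyclopropyl did not. Compound 1 and compound 3 both carry a six-membered aromatic ring at this place, so having such a ring does not by itself set the number, and what the ring carries matters in this pair. No measurement is available that explains the shift, so the change can be described but not accounted for.

From the compounds shown here alone, whether the amine itself matters stays open, and telling this would take a plain phenyl group, or a phenyl ring carrying a hydroxyl group or a carboxylic acid in its place. Going by these compounds, it is equally open whether the amine's place on the ring counts, and whether an amine on a non-aromatic group such as cyclopropyl would give a similar number.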